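Quinoline sulfones: fluorophenyl position and microsomal clearance

The compounds below may be only part of what the source reports. "The series", "measured", "known", "first", "only" and "open" are said of these compounds alone.

Measured so far in an ADME assay on microsomes from liver (Homo sapiens) for metabolic stability, tested at 2.5 uM; on this read-out higher numbers stand for fast clearance and lower numbers for slow clearance:
compound 1 `O=S(=O)(c1cc(Cl)cc(Cl)c1)c1cnc2c(F)cccc2c1-c1ccccc1F`, 0.44 mL/min
compound 2 `N#Cc1cccc(S(=O)(=O)c2cnc3c(F)cccc3c2-c2cccc(Cl)c2)c1`, 1.11 mL/min
compound 3 `N#Cc1cccc(S(=O)(=O)c2cnc3c(F)cccc3c2-c2cccc(F)c2)c1`, 0.34 mL/min

Compound 3 has the lowest number of the three, but its gap to compound 1 lies within the scatter; only compound 2 stands clearly apart from it. For the measured compounds named here, the one step in one place is a 3.3-fold lower number from compound 2 to compound 3 (0.51 log units; beyond the scatter).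

Compound 4 `N#Cc1cccc(S(=O)(=O)c2cnc3c(F)cccc3c2-c2ccccc2F)c1` differs from compound 3 by 2-fluorophenyl in place of 3-fluorophenyl on an aromatic carbon. Going by the values given here, no measured step covers this change; the fluoro for chloro step speaks to another part of the molecule. Compound 1 also carries the 2-fluorophenyl group, though it differs from compound 4 in a second place, and its number sits within the scatter of compound 3. On that basis no step beyond the scatter is expected, and compound 4 is estimated at 0.4 mL/min (range 0.2 mL/min to 0.8 mL/min), an expected step of a 1.2-fold higher number from compound 3 to compound 4 (0.07 log units; within the scatter).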

Compound 4, intrinsic clearance in a liver preparation (reported as CLH), per the amount of preparation that the assay uses: 0.66 mL/min
The estimate for compound 4 lay 1.7-fold (0.22 log units) below the measured number; low and high end bracket the measured number.
By their numbers in this assay, from the lowest: compounds 3, 1, 4 and 2 (each within the scatter of the next, the first and the last beyond it).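

In this assay, 2-fluorophenyl in place of 3-fluorophenyl gives a step within the scatter (a 1.9-fold higher number from compound 3 to compound 4 (0.29 log units; within the scatter)), so the two fluorophenyl groups are not told apart at this position. The step from 3-chlorophenyl to 2-fluorophenyl (a 1.7-fold lower number from compound 2 to compound 4 (0.23 log units; within the scatter)) and that from 3,5-dichlorophenyl to 3-cyanophenyl on the sulfonyl sulfur (a 1.5-fold higher number from compound 1 to compound 4 (0.18 log units; within the scatter)) also stay within the scatter, unlike the step to 3-fluorophenyl (a 3.3-fold lower number from compound 2 to compound 3 (0.51 log units; beyond the scatter)). Nothing available explains these numbers.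

Open, from the compounds shown here alone, is how a phenyl carrying a methoxy group or an amine would read at this position.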